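The source may report more compounds than this note shows. Statements on the series, on what has been measured and on what is new or still open speak of the compounds shown alone.

In a functional assay on DU-145 cells (Homo sapiens) for inhibition, read by trypan blue exclusion, with a stated time of 96 h (on this read-out higher numbers stand for weaker inhibition of growth and lower numbers for stronger inhibition of growth), compound 1 (`O=C(/C(=C\c1ccc(Br)cc1)Sc1ccc(Br)cc1)c1ccc(Br)cc1`) gives 1000 nM and sits level with compound 2 (`O=C(/C(=C\c1ccc(Br)cc1)Sc1ccccc1Br)c1ccc(Br)cc1`), which also gives 1000 nM at the digits shown. Among the compounds with values here, these two share the lowest number of the three measured so far, while compound 3 (`COc1ccc(S/C(=C/c2ccc(Br)cc2)C(=O)c2ccc(Br)cc2)cc1`) stands well apart at 20000 nM on the same read-out.

Compound 4 (`O=C(/C(=C\c1ccc(I)cc1)Sc1ccc(Br)cc1)c1ccc(Br)cc1`) keeps the core of compound 1 and makes one change: iodo in place of bromo on an aromatic carbon, para to a large group (iodo in place of bromo on an aromatic carbon).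

Within the data shown here, two measured steps bear on this change, though both sit on a different ring from the one altered here. Placing 2-bromophenyl in place of 4-bromophenyl on a sulfur left the number within the scatter (no change at the digits printed from compound 1 to compound 2 (within the scatter)), whereas methoxy in place of bromo gave a large step (a 20-fold higher number from compound 1 to compound 3 (1.30 log units; beyond the scatter)). Neither step swaps one halogen for another, so the data hold no direct measure of iodo. The large step came with a methoxy, which compound 4 does not carry, so the step without one (no change at the digits printed from compound 1 to compound 2 (within the scatter)) is taken as the better guide.

In this assay the expected step is therefore small (no change at the digits printed from compound 1 to compound 4 (within the scatter)), with neither direction favoured and nothing expected beyond the scatter. Compound 4 is estimated at 1000 nM with an expected range from 400 nM to 3000 nM in this measurement.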

Compound 4, concentration for 50% growth inhibition: 1000 nM
Beside the measured number, compound 4's estimate shows no gap at the digits printed; the measured number falls inside the stated range.
By their numbers in this assay, from the lowest: compounds 1, 2 and 4 (each within the scatter of the next); then compound 3.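

Within the data shown here, the earlier steps all altered the group on the sulfur, so compound 4 is the first to test a different place: an aromatic carbon of a six-membered aromatic ring of carbon only, para to a large group. In this assay, the change from 4-bromophenyl to 4-iodophenyl gives no change at the digits printed from compound 1 to compound 4 (within the scatter) and so leaves the number where it was, which shows that at this position one halogen can stand in for the other without a measurable loss of growth inhibition. No other measurement shown here speaks to why the number holds, and no explanation can be offered for this result.

From the compounds shown here alone, what remains open is how this position responds to a group of a different kind, such as a methoxy, an amine or a carboxylic acid, since a single halogen swap says little about those. The question matters most for methoxy, which on the group on the sulfur came with a 20-fold higher number from compound 1 to compound 3 (1.30 log units; beyond the scatter) in this assay and might or might not have a similar effect at this position.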